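The source may report more compounds than this note shows. Statements on the series, on what has been measured and on what is new or still open speak of the compounds shown alone.

Of the compounds shown here, three built on one shared core have been tested in a functional assay on NFF cells (Homo sapiens) for antiproliferative activity; a higher number here means a weaker inhibitor, a lower number a stronger inhibitor. Compound 1 `CN(C)c1ccc(C(=O)N[C@@H](CCCCCC(=O)NO)C(=O)NCc2ccccc2)cc1` gives 12000 nM in this assay. Compound 2 `O=C(/C=C/c1ccccc1)N[C@@H](CCCCCC(=O)NO)C(=O)NCc1ccccc1` gives 4010 nM. Compound 3 `O=C(CCCCC[C@H](NC(=O)OCc1ccccc1)C(=O)NCc1ccccc1)NO` gives 1520 nM, the lowest of the three numbers, and so the strongest inhibitor among them. The three steps that connect these compounds all change the group attached to a carbonyl carbon at one end of the core: a 3.0-fold lower number from compound 1 to compound 2 (0.48 log units; beyond the scatter), a 7.9-fold lower number from compound 1 to compound 3 (0.90 log units; beyond the scatter) and a 2.6-fold lower number from compound 2 to compound 3 (0.42 log units; beyond the scatter). Each of these steps is modest, yet each is larger than the scatter.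

Compound 4 `O=C(CCCCC[C@H](NC(=O)OCc1ccccc1)C(=O)Nc1ccc(-c2ccccc2)cc1)NO` keeps everything in compound 3 except the group at the other end: 4-phenylphenyl in place of benzyl on an amide-type nitrogen. Among the compounds with values here, none of the measured steps touches that amide nitrogen, so the measured data say nothing direct about this change; the expectation for compound 4 therefore rests only on compound 3 and carries a wide range. In this assay compound 4 is expected to give about 900 nM, with a likely range from 150 nM to 5000 nM. That estimate means an expected step of a 1.7-fold lower number from compound 3 to compound 4 (0.23 log units; within the scatter), a change that could fall within the scatter rather than beyond it.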

Compound 4, half-maximal inhibitory concentration: 2200 nM
Compound 4: the middle estimate sits 2.4-fold (0.39 log units) below what was measured; low and high end bracket the measured number.
By their numbers in this assay, from the lowest: compounds 3, 4 and 2 (each within the scatter of the next, the first and the last beyond it); then compound 1.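

Within the data shown here, every earlier step changed the group on the carbonyl carbon, so compound 4 gives the first reading at the other end of the shared core, on the amide-type nitrogen. In this assay, replacing benzyl with 4-phenylphenyl raises the count from 7 to 12 heavy atoms and adds a second six-membered aromatic ring, yet the result is a 1.4-fold higher number from compound 3 to compound 4 (0.16 log units; within the scatter), so this pair cannot be told apart. Unlike the three steps on the carbonyl carbon, each beyond the scatter, this single step on the nitrogen shows no measurable difference, and no evidence is available to explain the result.

One pair with two all-carbon aromatic groups leaves open whether this position would respond to a different kind of group, such as a 4-aminophenyl group, a 4-carboxyphenyl group or a benzyl group with a longer chain to its ring. It also leaves open whether 4-phenylphenyl on this nitrogen would give a similarly small step alongside the 2-phenylethenyl group of compound 2 or the 4-(dimethylamino)phenyl group of compound 1.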